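A few compounds are considered here, and "the series" means these few. Any claim that something is new, unique, unknown or untested is made for them only; others in the source may bear on it.

Three compounds have been measured in a functional assay on MCF7 cells (Homo sapiens) for inhibition, read by MTT assay, with a stated time of 72 h; on this read-out lower numbers stand for stronger inhibition of growth and higher numbers for weaker inhibition of growth:

Compound 1 `COc1ccc(CNCCCNS(=O)(=O)c2cc(C(F)(F)F)cc(C(F)(F)F)c2)cc1OC` gives 1900 nM.
Compound 2 `CN(CCCNS(=O)(=O)c1cc(C(F)(F)F)cc(C(F)(F)F)c1)Cc1ccccc1` gives 16000 nM.
Compound 3 `O=S(=O)(NCCCNCc1ccccc1)c1cc(C(F)(F)F)cc(C(F)(F)F)c1` gives 3000 nM.

Among these three, compound 3 holds the second highest number. Its nearest neighbour is compound 1: a 1.6-fold higher number from compound 1 to compound 3 (0.20 log units; within the scatter), a step within the scatter. Compound 2 stands furthest away: a 5.3-fold lower number from compound 2 to compound 3 (0.73 log units; beyond the scatter), a modest step beyond the scatter.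

Compound 4 `O=S(=O)(NCCCNCc1cccc(Cl)c1)c1cc(C(F)(F)F)cc(C(F)(F)F)c1` differs from compound 3 by one change: chloro in place of hydrogen on an aromatic carbon. Of the two measured steps, only one touches the same part of the molecule, the ring on the saturated chain carbon bound to the amine nitrogen, and there the exchange of phenyl for 3,4-dimethoxyphenyl, a 1.6-fold higher number from compound 1 to compound 3 (0.20 log units; within the scatter), stayed within the scatter. The other step, a 5.3-fold lower number from compound 2 to compound 3 (0.73 log units; beyond the scatter), concerns a hydrogen in place of methyl on the amine nitrogen and does not bear on a change at an aromatic carbon. With chloro entering on a ring where a larger exchange gave no shift beyond the scatter, no step beyond the scatter is expected in this assay; the expected step is a 1.2-fold lower number from compound 3 to compound 4 (0.08 log units; within the scatter). Compound 4 is therefore estimated at 2500 nM, with a range from 1000 nM to 7000 nM.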

Compound 4, concentration for 50% growth inhibition: 2600 nM
The estimate for compound 4 lay 1.0-fold (0.02 log units) below the measured number, within the range that was stated.
By their numbers in this assay, from the lowest: compounds 1, 4 and 3 (each within the scatter of the next); then compound 2.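

Going by these compounds alone, a chloro on this aromatic carbon, in place of hydrogen, produces no shift beyond the scatter in this assay (a 1.2-fold lower number from compound 3 to compound 4 (0.06 log units; within the scatter)), which is the first direct reading of a substituent added to the phenyl ring of compound 3. The exchange between the two substituted rings also stays within the scatter (a 1.4-fold higher number from compound 1 to compound 4 (0.14 log units; within the scatter)), so phenyl, 3-chlorophenyl and 3,4-dimethoxyphenyl cannot be told apart in these numbers. The chloro also leaves the contrast with compound 2 in place, as the change from benzyl(methyl)amino to (3-chlorobenzyl)amino is a modest step beyond the scatter (a 6.2-fold lower number from compound 2 to compound 4 (0.79 log units; beyond the scatter)), so among these compounds the one clear difference still goes with the methyl on the amine nitrogen.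

Nothing available explains why these numbers fall as they do. The compounds shown leave open whether chloro on another carbon of the ring, or a nitrile or a carboxylic acid on that ring, would shift the number beyond the scatter, and whether a longer chain between the sulfonamide nitrogen and the amine nitrogen would do so.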